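This account rests on a few compounds, and the source may have more. Where it says the series, first, only, none or still open, it means among the compounds named here.

Measured so far in a functional assay on HEK293 cells for activation of melanin-concentrating hormone receptor 1 (Homo sapiens), read by inositol phosphate accumulation; on this read-out higher numbers stand for an effect only at larger amounts of compound and lower numbers for an effect already at smaller amounts:
Compound 1 `CCCc1cc(N2CCCC2)c2cc(NC(=O)/C=C/c3ccc(C(F)(F)F)cc3)ccc2n1` gives 2800 nM.
Compound 2 `Cc1cc(N)c2cc(NC(=O)/C=C/c3ccc(C(F)(F)F)cc3)ccc2n1` gives 140 nM.

Of these two numbers, compound 1 has the higher one, and the gap between compound 1 and compound 2 lies well beyond the usual scatter, so compound 1 is the one that needs the larger amount to act. The two compounds differ in more than one place, so no single change can be read from that gap.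

Compound 3 `CCCc1cc(OC)c2cc(NC(=O)/C=C/c3ccc(C(F)(F)F)cc3)ccc2n1` is not yet measured. It comes from compound 1 by one change: methoxy in place of pyrrolidin-1-yl on an aromatic carbon. The group that enters is much smaller than the one that leaves, and compound 2, which carries a small group at the same part of the shared core, shows the lower number. On that basis the step in this assay is expected to lower the number, with the estimate for the change a 3.5-fold lower number from compound 1 to compound 3 (0.54 log units; beyond the scatter). For the measured compounds named here, since only one measured pair exists and it differs in two places, the expected size is uncertain. Compound 3 is estimated at 800 nM, in the range 200 nM to 3000 nM.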

Compound 3, half-maximal effective concentration: 360 nM
For compound 3 the middle estimate is 2.2-fold (0.35 log units) above the measured one; the measured number falls inside the stated range.
By their numbers in this assay, from the lowest: compound 2; then compound 3; then compound 1.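

In this assay, putting methoxy in place of pyrrolidin-1-yl on the aromatic carbon opposite the ring nitrogen, with the propyl group and the rest of the molecule unchanged, gives a 7.8-fold lower number from compound 1 to compound 3 (0.89 log units; beyond the scatter). For the compounds shown here, this is the first comparison here that isolates one place, and it shows that the group on this carbon alone can shift the number by more than the usual scatter, something the pair of compound 1 and compound 2, which differ in more than one place, could not show. The change takes away a ring and goes from 5 heavy atoms to 2, with 0 hydrogen-bond donors and 1 hydrogen-bond acceptor on both sides, but no measurement here explains why the number falls.

One step cannot separate the loss of the ring, the smaller heavy-atom count and the swap of nitrogen for oxygen on this carbon. Still open, on these data alone, is how a dimethylamino group, which keeps the nitrogen without the ring, or an ethoxy group, which lengthens the oxygen-linked chain, would compare on the same propyl-bearing core.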